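Nitrophenyl in place of fluorophenyl on an amine nitrogen

The source may hold more compounds than are shown below. What is called first, only, known or untested is meant among the compounds shown, and "the series" means these compounds.

compound 1: `CCOC(=O)C1=C(Nc2ccccc2)S/C(=C\c2ccccc2O)C1=O` — 8800 nM
compound 2: `CCOC(=O)C1=C(Nc2ccc(F)cc2)S/C(=C\c2ccc[nH]2)C1=O` — a limit, > 100000 nM

In a functional assay on K562 cells (Homo sapiens) for inhibition, read by MTT assay, with a stated time of 72 h (a lower number here means a stronger inhibitor, a higher number a weaker inhibitor), compound 1 gives 8800 nM. Compound 2 does not give a number in this assay but only a limit, > 100000 nM. This is the limit of > 100000 nM in this assay, at which 1 of the 2 values shown sits. Among the measured compounds shown here, the two compounds differ in more than one place, and no step between them is laid out; their values show only that compound 1 has a number and compound 2 does not.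

Compound 3, `CCOC(=O)C1=C(Nc2cccc([N+](=O)[O-])c2)S/C(=C\c2ccc[nH]2)C1=O`, is still to be measured. It differs from compound 2 by 3-nitrophenyl in place of 4-fluorophenyl on an amine nitrogen. For the measured compounds named here, no measured step bears on this change, and compound 2 itself stands at a limit, which gives no footing for a direction. The expected step from compound 2 to compound 3 is a number no higher from compound 2 to compound 3 (the limit leaves the size open), that is, none beyond the scatter. Compound 3 is expected at 100000 nM, within 20000 nM to 300000 nM, and most likely reported again only as a limit.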

Compound 3, half-maximal inhibitory concentration: 7200 nM
The estimate for compound 3 lay 14-fold (1.14 log units) above the measured number, outside the stated range (below it).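

In this assay, placing 3-nitrophenyl instead of 4-fluorophenyl on the amine nitrogen gives an at least 13-fold lower number from compound 2 to compound 3 (1.14 log units; beyond the scatter). This shows that, with the rest of the structure unchanged, the group at this one position can separate a compound that gives a number, compound 3, from one that gives only a limit, compound 2. Compound 2 stands at a limit and not at a number, so the step sets only a floor on the size of the change: the limit of > 100000 nM in this assay, at which 1 of the 3 values shown sits.

As far as these compounds go, whether the step rests on the nitro group, on the loss of the fluorine or on the different place of the substituent on the phenyl ring stays open, as these three change together here. From the compounds shown here alone, how an amine or a carboxylic acid in the place of the nitro group would read in this assay also stays open.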